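The compounds below may be only part of what the source reports. "The series", "measured", "known", "first", "only" and "open" are said of these compounds alone.

Measured compounds:
Compound 1 `CC(CC(=O)/N=C(\N)NCCCc1ccncc1)c1ccccc1` — in an assay on isolated protein for positive allosteric modulation of histamine H2 receptor (Cavia porcellus), with a stated time of 30 min (on this read-out lower numbers stand for lower potency and higher numbers for higher potency (the scale is a negative logarithm)), compound 1 gives 4.54.
Compound 2 `CC(CC(=O)/N=C(\N)NCCCn1ccnc1)c1ccccc1` — in this assay compound 2 gives 4.16.

Compound 2 stands lowest of the two numbers; its nearest neighbour, compound 1, lies higher by a number 0.38 log units lower from compound 1 to compound 2 (beyond the scatter). Compound 3 `CC(CC(=O)/N=C(\N)NCCCc1ncc[nH]1)c1ccccc1` is unmeasured and differs from compound 2 by 1H-imidazol-2-yl in place of 1H-imidazol-1-yl on a saturated chain carbon, three bonds along the chain from an amine nitrogen. Among the compounds with values here, only one measured step bears on this, the exchange of one ring for another at the same place, which was of modest size and beyond the scatter. A change of similar modest size is therefore expected for compound 3, with the direction uncertain, estimated as a number 0.19 log units higher from compound 2 to compound 3 (within the scatter). For compound 3 the expected value is 4.35, with a range from 3.9 to 4.85.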

Compound 3, negative logarithm of the half-maximal effective concentration: 4.44
The estimate for compound 3 lay 0.09 log units below the measured number; the measured number falls inside the stated range.
By their numbers in this assay, from the lowest: compounds 2, 3 and 1 (each within the scatter of the next, the first and the last beyond it).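

Exchanging 1H-imidazol-1-yl for 1H-imidazol-2-yl in this assay gives a number 0.28 log units higher from compound 2 to compound 3 (within the scatter), so with the same atoms joined differently, this change stays within the scatter. The exchange of pyridin-4-yl for 1H-imidazol-2-yl gives a number 0.10 log units lower from compound 1 to compound 3 (within the scatter), whereas the exchange for 1H-imidazol-1-yl had moved beyond it, so at this position the outcome of replacing pyridin-4-yl depends on how the imidazole ring is attached. Nothing shown here explains that difference. Still open, as far as these compounds go, is how 1H-imidazol-4-yl would compare at this place, and whether a plain amine in place of the ring would hold up.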